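The source may hold more compounds than are shown below. What is called first, only, known or untested is meant among the compounds shown, and "the series" means these compounds.

Compound 3 `O=C(O)c1cncn1Cc1cc(Br)ccc1OCc1ccccc1` carries a 5-carboxy-1H-imidazol-1-yl group on the saturated chain carbon bound to an aromatic carbon. In a functional assay on CHO-K1 cells for antagonist activity at prostaglandin E2 receptor EP1 subtype (Homo sapiens), read by FLIPR (on this read-out higher numbers stand for weaker inhibition and lower numbers for stronger inhibition), compound 3 gives only a limit, < 2000 nM. Compound 1 `O=C(O)c1ccn(Cc2cc(Br)ccc2OCc2ccccc2)n1`, which bears 3-carboxy-1H-pyrazol-1-yl at the same place, gives 55 nM in this assay. Compound 2 `CC(=O)Nc1cc(C(=O)O)nn1Cc1cc(Br)ccc1OCc1ccccc1` carries acetamido in place of hydrogen on an aromatic carbon of the shared core; in this assay compound 2 also gives only a limit, < 2000 nM. From the compounds shown here alone, because of the limit of < 2000 nM in this assay, at which 2 of the 3 values shown sit, neither a step that the limit leaves unreadable from compound 1 to compound 3 nor a step that the limit leaves unreadable from compound 1 to compound 2 can be read in size, so where compound 3 stands against compound 1 remains open.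

Compound 4 `O=C(O)c1cnn(Cc2cc(Br)ccc2OCc2ccccc2)c1` differs from compound 3 by the change (4-carboxy-1H-pyrazol-1-yl in place of 5-carboxy-1H-imidazol-1-yl on a saturated chain carbon bound to an aromatic carbon). Among the measured compounds shown here, no measured step covers this exchange of one carboxy-bearing five-membered ring for another, and the limit for compound 3 leaves no number to step from. What remains is that compound 1, with a carboxy-bearing ring of the same size at the same place, gives 55 nM in this assay.

Compound 4 is therefore expected to give 400 nM, with a range from 40 nM to 4000 nM. The estimated step that the limit leaves unreadable from compound 3 to compound 4 is read against a limit only and carries wide uncertainty in either direction.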

Compound 4, inhibition constant: < 2000 nM
Compound 4: only a limit was reported; the forecaster's own chance of this, stated with the estimate: 30%; the middle value is on the limit's open side.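

Neither the comparison of compound 4 with compound 3 nor that of compound 4 with compound 1 gives a step of readable size in this assay, because of one shared limit: the limit of < 2000 nM in this assay, at which 3 of the 4 values shown sit.

From the compounds shown here alone, how far compound 2, compound 3 and compound 4 each stand from compound 1, and whether compound 3 and compound 4 differ at all, remains open.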